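A few compounds are considered here, and "the series" means these few. Any claim that something is new, unique, unknown or untested is made for them only; others in the source may bear on it.

Measured so far in this series:
compound 1, `CC(=O)OC[C@H]1O[C@@H](n2cc(CN3C(=O)/C(=C\c4ccco4)c4ccccc43)nn2)[C@H](OC(C)=O)[C@@H](OC(C)=O)[C@@H]1OC(C)=O`: 13300 nM
compound 2, `CCC/C=C1/C(=O)N(Cc2cn([C@@H]3O[C@H](COC(C)=O)[C@@H](OC(C)=O)[C@H](OC(C)=O)[C@H]3OC(C)=O)nn2)c2ccccc21`: > 100000 nM

In an ADME assay on NIH3T3 cells (Homo sapiens) for cytotoxicity, read by sulforhodamine B assay, with a stated time of 48 h (a higher number here means a weaker inhibitor, a lower number a stronger inhibitor), compound 1 gives 13300 nM. For compound 2 the assay reports only a limit, > 100000 nM, so no number stands for it. the limit of > 100000 nM in this assay, at which 1 of the 2 values shown sits, marks where that limit sits. Compound 3, `CCC/C=C1\C(=O)N(Cc2cn([C@@H]3O[C@H](COC(C)=O)[C@@H](OC(C)=O)[C@H](OC(C)=O)[C@H]3OC(C)=O)nn2)c2ccccc21`, has not yet been measured. It differs from compound 2 as follows: the two compounds have the same atoms and bonds and differ only in configuration as drawn: 1 of 6 stereo elements differ; a double bond is drawn E in compound 2 and Z in compound 3. No step between two measured compounds is shown, and nothing in the two values above tells how the geometry of that double bond moves the read-out; the starting point is itself a limit. No shift beyond the usual scatter is expected, and the likeliest outcome is that compound 3 is again reported as a limit. Compound 3 is estimated at 100000 nM, with a range from 30000 nM to 300000 nM. The step this estimate implies is a number no higher from compound 2 to compound 3 (the limit leaves the size open).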

Compound 3, half-maximal inhibitory concentration: > 100000 nM
Compound 3 ended at the assay's limit; the forecaster's own chance of this, stated with the estimate: 60%; the middle value lies on the limit itself.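

In this assay compound 3 is reported only as a limit, > 100000 nM and not as a number. Propyl in place of furan-2-yl on a double-bonded chain carbon bound to a double-bonded ring carbon gives an at least 7.5-fold higher number from compound 1 to compound 3 (0.87 log units; beyond the scatter) and this holds for the Z-drawn propyl compound as well, so neither drawn geometry of the propyl compound gives a reading inside the range of the assay. The step between the two geometries cannot be read because compound 2 and compound 3 both end at the same limit: the limit of > 100000 nM in this assay, at which 2 of the 3 values shown sit.

On these data alone, whether the geometry of the double bond moves the read-out at all stays open, including for the furan-2-yl compound. Also open, as far as these compounds go, is whether a longer chain such as hexyl, or a phenyl ring, in place of propyl would bring the reading back inside the limit.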